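This account rests on a few compounds, and the source may have more. Where it says the series, first, only, none or still open, it means among the compounds named here.

Working notes on the series. Within the data shown here, the three measured members share one core and differ only in the group on a saturated chain carbon bound to an amine nitrogen in a ring. In a functional assay on the whole organism for antagonist activity, with Mus musculus as the target (a higher number here means that more compound is needed for the effect, a lower number that less compound is needed), compound 1 `CCCCN1CCC(C(=O)Nc2cc(Cl)c(N)cc2OC)CC1` reaches no number, only a limit of the assay, > 10 mg/kg. Compound 2 `COc1cc(N)c(Cl)cc1NC(=O)C1CCN(Cc2ccc([N+](=O)[O-])cc2)CC1` likewise stops at a limit of the assay in this assay, > 4 mg/kg. Compound 3 `COc1cccc(CN2CCC(C(=O)Nc3cc(Cl)c(N)cc3OC)CC2)c1` also gives only a limit of the assay in this assay, > 4 mg/kg. Compound 3 thus stands at the limit of > 4 mg/kg in this assay, at which 2 of the 3 values shown sit, and no order among the three can be read: a step that the two limits leave unreadable from compound 1 to compound 2, a step that the two limits leave unreadable from compound 1 to compound 3 and a step that the two limits leave unreadable from compound 2 to compound 3 are all of unreadable size, since one value sits at the limit of > 10 mg/kg in this assay, at which 1 of the 3 values shown sits, and two at the limit of > 4 mg/kg in this assay, at which 2 of the 3 values shown sit.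

The next member is compound 4 `COc1cc(N)c(Cl)cc1NC(=O)C1CCN(Cc2cccc(Cl)c2)CC1`, reached from compound 3 by chloro in place of methoxy on an aromatic carbon, meta to a large group. Among the measured compounds shown here, none of the measured steps touches this position, and none carries a readable size that could be transferred. In this assay compound 4 is therefore expected to stay near the same limits, the estimated step being a step that the limit leaves unreadable from compound 3 to compound 4. The estimate for compound 4 is 6 mg/kg, with a range from 2 mg/kg to 20 mg/kg, and a limit rather than a number is the more likely report.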

Compound 4, dose for half-maximal effect: > 4 mg/kg
Compound 4 gave a limit, no number; the forecaster's own chance of this, stated with the estimate: 75%; the middle value is on the limit's open side.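

Among these compounds, compound 4 also gives only a limit of the assay in this assay, > 4 mg/kg, so no step from compound 1, compound 2 or compound 3 to compound 4 can be read. The compounds shown leave open how large a dose any of these groups on the saturated chain carbon needs in this assay, and how chloro and methoxy compare there.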